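Repeating the acetyl exchange on the allyl core

The source may hold more compounds than are shown below. What is called first, only, known or untested is meant among the compounds shown, and "the series" means these compounds.

Measured compounds:
compound 1 `CCn1c(SCC(=O)Nc2ccc(/C(C)=N/O)cc2)nnc1-c1ccc(OC)cc1`: 60%
compound 2 `CCn1c(SCC(=O)Nc2ccc(C(C)=O)cc2)nnc1-c1ccc(OC)cc1`: 57%
compound 3 `C=CCn1c(SCC(=O)Nc2ccc(/C(C)=N/O)cc2)nnc1-c1ccc(OC)cc1`: 63%

All three values come from a functional assay on the whole organism (strain albino) for inhibition, with Rattus norvegicus as the target, read by paw edema, with stated times of 30 min and 3 h, at a dose of 0.28 mmol/kg by the oral route; a lower number here means less inhibition, a higher number more inhibition at the dose given (going by the name of the read-out). Compound 2 differs from compound 1 by a group of 3 heavy atoms (2 carbon, 1 oxygen; no ring) in place of a group of 4 heavy atoms (2 carbon, 1 nitrogen, 1 oxygen; no ring), on an aromatic carbon; the step is a number 3 percentage points lower from compound 1 to compound 2 (within the scatter). Compound 3 differs from compound 1 only in the core, by vinyl in place of methyl on a saturated chain carbon bound to an aromatic nitrogen; the step is a number 3 percentage points higher from compound 1 to compound 3 (within the scatter). The three values lie within the scatter of one another, so no order among compound 1, compound 2 and compound 3 is claimed.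

Compound 4 `C=CCn1c(SCC(=O)Nc2ccc(C(C)=O)cc2)nnc1-c1ccc(OC)cc1` is not yet measured. It differs from compound 3 by a group of 3 heavy atoms (2 carbon, 1 oxygen; no ring) in place of a group of 4 heavy atoms (2 carbon, 1 nitrogen, 1 oxygen; no ring), on an aromatic carbon. This is the same change as from compound 1 to compound 2, at the same place, and it occurs twice among the compounds shown; the only other difference between the two pairs is the core, given above by vinyl in place of methyl on a saturated chain carbon bound to an aromatic nitrogen.

For compound 4 a step of a number 3 percentage points lower from compound 3 to compound 4 (within the scatter) is expected in this assay, resting on the one earlier occurrence, a number 3 percentage points lower from compound 1 to compound 2 (within the scatter), which stayed within the scatter. Compound 4 is therefore estimated at 60%, with a range of 50% to 70% expected.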

Compound 4, a percentage reported as inhibition, in the whole organism at one dose (the size of the read-out at that dose, not a potency): 52%
Beside the measured number, compound 4's estimate is 8 percentage points above it; the measured number falls inside the stated range.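

On the core of compound 3, the acetyl exchange in this assay gives a number 11 percentage points lower from compound 3 to compound 4 (beyond the scatter), whereas on the core of compound 1 the same exchange stayed within the scatter, yet the two steps cannot be told apart: the same change on two cores in this assay, a number 3 percentage points lower (within the scatter) from compound 1 to compound 2 and a number 11 percentage points lower (beyond the scatter) from compound 3 to compound 4, 8 percentage points apart, within the scatter of two such steps. The change of core, read on the acetyl pair, gives a number 5 percentage points lower from compound 2 to compound 4 (within the scatter), and this too agrees with its earlier occurrence: the same change on two cores in this assay, a number 3 percentage points higher (within the scatter) from compound 1 to compound 3 and a number 5 percentage points lower (within the scatter) from compound 2 to compound 4, 8 percentage points apart, within the scatter of two such steps. The exchange therefore carries between these two cores without a demonstrated difference in the size of the step, but two pairs neither prove that the core has no influence nor show how the exchange would behave on any further core.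

The compounds shown leave open how the read-out responds when a carboxylic acid or an amine stands in place of the acetyl, or when a longer chain replaces the allyl group. All values come from a single dose, so they leave potency open as well.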